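Working notes: the step from compound 2 to compound 4

The source may report more compounds than this note shows. Statements on the series, on what has been measured and on what is new or still open speak of the compounds shown alone.

Values in a functional assay on SGC-7901 cells (Homo sapiens) for antiproliferative activity, read by MTT assay, with a stated time of 24 h (on this read-out higher numbers stand for weaker inhibition and lower numbers for stronger inhibition), are as follows:
compound 1 `Cc1ccccc1NNC(=O)c1cccc(NS(=O)(=O)c2cnc(O)nc2O)c1` gives > 20000 nM as a limit
compound 2 `Cc1ccccc1NNC(=O)c1ccccc1NS(=O)(=O)c1cnc(O)nc1O` gives > 20000 nM as a limit
compound 3 `Cc1ccccc1C(=O)NNC(=O)c1cccc(NS(=O)(=O)c2cnc(O)nc2O)c1` gives > 20000 nM as a limit

Compound 2 stands only at a limit (> 20000 nM) and offers no number to step from. Among the compounds with values here, the series so far shows the limit of > 20000 nM in this assay, at which 3 of the 3 values shown sit, and no measured number. Compound 4 `Cc1ccc(C(=O)NNC(=O)c2ccccc2NS(=O)(=O)c2cnc(O)nc2O)cc1` carries the change (4-methylphenyl)carbonyl in place of 2-methylphenyl on an amine nitrogen in which (4-methylphenyl)carbonyl replaces 2-methylphenyl on an amine nitrogen. Within the data shown here, the only measured step of this kind is a step that the two limits leave unreadable from compound 1 to compound 3 so no size or direction beyond the scatter is expected in this assay for this change. The estimated step is a step that the limit leaves unreadable from compound 2 to compound 4 and it carries little weight. Compound 4 is expected at 25000 nM with an estimated range of 8000 nM to 60000 nM and may well return only a limit.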

Compound 4, half-maximal inhibitory concentration: 15500 nM
Compound 4: middle estimate off by 1.6-fold (0.21 log units), on the high side, within the range that was stated.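

In this assay, within the data shown here, compound 4 gives the first measured number of the series, while the other compounds remain at a limit: the limit of > 20000 nM in this assay, at which 3 of the 4 values shown sit.
On the amine nitrogen, (4-methylphenyl)carbonyl in place of 2-methylphenyl gives an at least 1.2-fold lower number from compound 2 to compound 4 (0.11 log units; that floor lies within the scatter), so this position can yield a readable value, but no gain beyond the scatter is established.

The compounds shown do not separate the effect of the carbonyl from that of the methyl's place on the phenyl ring. As far as these compounds go, whether an amine or a carboxylic acid in place of that methyl would move the value further also stays open.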